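A few compounds are considered here, and "the series" means these few. Any claim that something is new, unique, unknown or untested is made for them only; others in the source may bear on it.

Compound 3 `COCc1cccc(CNC(=O)c2nn(-c3ccc(F)cc3)c(OC[C@@H](O)C[C@@H](O)CC(=O)O)c2C(C)C)c1` gives 31 nM in an assay on microsomes from liver for inhibition of 3-hydroxy-3-methylglutaryl-coenzyme A reductase (Rattus norvegicus); on this read-out higher numbers stand for weaker inhibition and lower numbers for stronger inhibition. Among the three compounds measured it has the highest number: compound 2 `CC(C)c1c(C(=O)NCc2ccccn2)nn(-c2ccc(F)cc2)c1OC[C@@H](O)C[C@@H](O)CC(=O)O` gives 25 nM, and the two lie within the scatter of each other (a 1.2-fold higher number from compound 2 to compound 3 (0.09 log units; within the scatter)), whereas compound 1 `Cc1ccc(CNC(=O)c2nn(-c3ccc(F)cc3)c(OC[C@@H](O)C[C@@H](O)CC(=O)O)c2C(C)C)cc1` gives 15 nM, and the difference from compound 1 to compound 3 is beyond the scatter (a 2.1-fold higher number from compound 1 to compound 3 (0.32 log units; beyond the scatter)). The remaining step, a 1.7-fold higher number from compound 1 to compound 2 (0.22 log units; within the scatter), is also within the scatter.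

Compound 4 `CC(C)c1c(C(=O)N(C)Cc2cccc(Cl)c2)nn(-c2ccc(F)cc2)c1OC[C@@H](O)C[C@@H](O)CC(=O)O` differs from compound 3 in one place: (3-chlorobenzyl)(methyl)amino in place of (3-(methoxymethyl)benzyl)amino on a carbonyl carbon. The measured steps all exchange the aryl group on the saturated chain carbon bound to the amide nitrogen and produce at most a modest movement; none of them removes the hydrogen on that nitrogen, which the step to compound 4 does in addition to the aryl exchange. The bearing of the measured steps is therefore partial, and the expectation rests on their small size alone. A small weakening in this assay is expected for compound 4, by a 1.9-fold higher number from compound 3 to compound 4 (0.29 log units; within the scatter), with a wide range. The estimate for compound 4 is 60 nM, between 15 nM and 250 nM.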

Compound 4, half-maximal inhibitory concentration: 8.3 nM
Estimate against measurement, compound 4: 7.2-fold (0.86 log units) above, and the stated range ends above it.
By their numbers in this assay, from the lowest: compounds 4, 1, 2 and 3 (each within the scatter of the next, the first and the last beyond it).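

For the compounds shown here, every earlier compound kept the amide hydrogen, so compound 4 is the first to show that this position tolerates its loss, along with a methyl on the amide nitrogen and a chlorine on the benzyl ring, without any weakening in this assay: the exchange gives a 3.7-fold lower number from compound 3 to compound 4 (0.57 log units; beyond the scatter) and a 3.0-fold lower number from compound 2 to compound 4 (0.48 log units; beyond the scatter), both beyond the scatter, whereas a 1.8-fold lower number from compound 1 to compound 4 (0.26 log units; within the scatter) stays within it. Going by these compounds alone, the exchange therefore separates compound 4 from two of the earlier compounds but not from compound 1. No measurement is available here to explain the result.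

Since the methyl and the chlorine enter together, the compounds shown leave open how much of the change belongs to each. A (3-chlorobenzyl)amino group, which keeps the amide hydrogen, or an ethyl group on that nitrogen would bear on this question.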